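A second chloro on the benzoate of compound 3

A few compounds are considered here, and "the series" means these few. Any claim that something is new, unique, unknown or untested is made for them only; others in the source may bear on it.

Three esters of the same phenol have been tested in an assay on isolated protein for antagonist activity at Bile acid receptor (Homo sapiens), read by HTRF, with a stated time of 30 min; a lower number here means a stronger inhibitor, a higher number a weaker inhibitor. Compound 1 `CC(C)(C)c1cc(OC(=O)c2ccc(Cl)cc2Cl)ccc1O` gives 10200 nM. Compound 2 `COc1ccccc1C(=O)Oc1ccc(O)c(C(C)(C)C)c1` returns only a limit of the assay, > 100000 nM, which is the limit of > 100000 nM in this assay, at which 1 of the 3 values shown sits. Compound 3 `CC(C)(C)c1cc(OC(=O)c2ccc([N+](=O)[O-])cc2Cl)ccc1O` gives 8800 nM, the lowest of the two numbers that are numbers at all, with compound 1 nearest to it. Within the data shown here, the one step between measured compounds that differ in a single place, a 1.2-fold lower number from compound 1 to compound 3 (0.06 log units; within the scatter), is within the scatter.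

Compound 4 `CC(C)(C)c1cc(OC(=O)c2c(Cl)cc([N+](=O)[O-])cc2Cl)ccc1O` differs from compound 3 by chloro in place of hydrogen on an aromatic carbon; the chloro enters on an aromatic carbon of a six-membered aromatic ring of carbon only, ortho to a large group and meta to both the chloro group and the nitro group already present. Among the measured compounds shown here, no measured step replaces hydrogen by chloro, so none bears directly on this change. For the measured compounds named here, the only measured step, from compound 1 to compound 3, stayed within the scatter, and a change of a single halogen on this ring is therefore expected to move this assay little, with no direction favoured beyond the scatter. Compound 4 is thus expected to give 7500 nM, between 2500 nM and 25000 nM, an estimated step of a 1.2-fold lower number from compound 3 to compound 4 (0.07 log units; within the scatter) from compound 3 to compound 4.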

Compound 4, half-maximal inhibitory concentration: 5900 nM
Compound 4: the middle estimate sits 1.3-fold (0.10 log units) above what was measured, within the range that was stated.
By their numbers in this assay, from the lowest: compounds 4, 3 and 1 (each within the scatter of the next). At a limit, above all of these: compound 2.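

Among these compounds, the step of a 1.5-fold lower number from compound 3 to compound 4 (0.17 log units; within the scatter) gives the first reading at this position of the benzoate, an aromatic carbon ortho to a large group and meta to both the chloro group and the nitro group, which carries hydrogen in compound 1 and compound 3. In this assay, this position therefore accepts a chloro in place of hydrogen with no change beyond the scatter, and the ring of compound 4 can carry this added atom while its number stays within the scatter of that of compound 3. The data show only this single replacement on one ester, and nothing shown accounts for the size of the step or shows a cause for it.

On these data alone, whether an amine, a carboxylic acid or a longer chain on this same aromatic carbon would also stay within the scatter of compound 4 remains open. As far as these compounds go, it is equally open whether chloro in place of hydrogen would give a similar step on a benzoate without the nitro group.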